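This account rests on a few compounds, and the source may have more. Where it says the series, first, only, none or still open, it means among the compounds named here.

Measured in a functional assay on U-87MG ATCC cells for inhibition, with U-87 MG (Homo sapiens) as the target, read by MTT assay, with a stated time of 48 h; on this read-out higher numbers stand for weaker inhibition and lower numbers for stronger inhibition:
Compound 1 `Cc1ccc(-c2nc3ccccn3c2Sc2ccccc2)cc1`: > 100000 nM, a limit of the assay and not a number
Compound 2 `C(=C/c1nc2ccccn2c1Sc1ccccc1)\c1ccccc1`: 59200 nM

Among the compounds with values here, compound 2 holds the only true number so far in this assay, which is 59200 nM. The only other result is the limit of > 100000 nM in this assay, at which 1 of the 2 values shown sits.

Compound 3 `CSc1ccc(-c2nc3ccccn3c2Sc2ccccc2)cc1` carries 4-(methylsulfanyl)phenyl in place of 2-phenylethenyl on an aromatic carbon. Within the data shown here, one measured step bears on this change, and it concerns the same kind of swap: an at least 1.6-fold lower number from compound 1 to compound 2 (0.22 log units; that floor lies within the scatter). That step put 2-phenylethenyl in place of 4-methylphenyl, whereas compound 3 goes back to a substituted phenyl group. Its size is only a floor, so it gives a weak guide. A small move towards a higher number, meaning weaker inhibition, therefore seems likelier than a gain, and the assay may again report only a limit. The estimated change is a 1.4-fold higher number from compound 2 to compound 3 (0.13 log units; within the scatter), and a step beyond the scatter is not expected. Compound 3 is expected at about 80000 nM, with an estimated range from 35000 nM to 180000 nM.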

Compound 3, half-maximal inhibitory concentration: 26900 nM
Compound 3: middle estimate off by 3.0-fold (0.47 log units), on the high side; measured number outside the range, below it.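

In this assay, putting 4-(methylsulfanyl)phenyl in place of 2-phenylethenyl on this aromatic carbon gives a 2.2-fold lower number from compound 2 to compound 3 (0.34 log units; beyond the scatter), so a substituted phenyl group here can beat the 2-phenylethenyl group, a result the earlier pair could not show. The two phenyl compounds also differ in one small group, and methylsulfanyl in place of methyl gives an at least 3.7-fold lower number from compound 1 to compound 3 (0.57 log units; beyond the scatter), which shows that the end group on that phenyl ring matters for the read-out and not only the kind of group on the core. The size of this second step is only a floor, because compound 1 has no true number and its result is a limit of the assay: the limit of > 100000 nM in this assay, at which 1 of the 3 values shown sits.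

The compounds shown leave open whether an amine, a carboxylic acid or a longer chain such as butylsulfanyl in place of the methylsulfanyl group would lower the number further, and whether the gain holds when the phenylsulfanyl group on the core is changed. They also cannot tell why the number falls, as one sulfur-bearing group on its own separates no possible explanation from another.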